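From methylsulfanyl to methyl: expected clearance of compound 3

The source may hold more compounds than are shown below. What is called first, only, known or untested is meant among the compounds shown, and "the series" means these compounds.

Among the compounds with values here, in an ADME assay on microsomes from liver (Homo sapiens) for metabolic stability, read by LC-MS (a lower number here means slower removal, a higher number faster removal of the compound), compound 2 `CSc1nnc2ccc(N[C@H]3CC[C@@H](Nc4ccnc(C(F)(F)F)n4)CC3)nn12` gives 29 mL.min-1.g-1, the only actual number available in this short series. Compound 1 `FC(F)(F)c1nccc(N[C@H]2CC[C@@H](Nc3ccc4nncn4n3)CC2)n1`, which carries hydrogen at the same aromatic carbon, gives < 3 mL.min-1.g-1, and this is a limit of the assay and not a number. Methylsulfanyl in place of hydrogen on an aromatic carbon therefore corresponds to an at least 9.6-fold higher number from compound 1 to compound 2 (0.98 log units; beyond the scatter), a step beyond the scatter and the only measured step that bears on the next change. Compound 3 `Cc1nnc2ccc(N[C@H]3CC[C@@H](Nc4ccnc(C(F)(F)F)n4)CC3)nn12` carries methyl in place of methylsulfanyl on an aromatic carbon. Within the data shown here, it thus partly returns toward compound 1 in size, so with an at least 9.6-fold higher number from compound 1 to compound 2 (0.98 log units; beyond the scatter) as the only guide, a lower number in this assay is expected. The expected change is a 3.2-fold lower number from compound 2 to compound 3 (0.51 log units; beyond the scatter), a fall beyond the scatter but probably not the full reversal. Compound 3 is estimated at 9 mL.min-1.g-1, with an expected range of 3.5 mL.min-1.g-1 to 24 mL.min-1.g-1.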

Compound 3, intrinsic clearance in microsomes: < 3 mL.min-1.g-1
Compound 3 gave a limit, no number (the forecaster's own chance of this, stated with the estimate: 15%); at least 3.0-fold (0.47 log units) between middle value and limit.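

In this assay, within the data shown here, methyl in place of methylsulfanyl on this aromatic carbon gives an at least 9.6-fold lower number from compound 2 to compound 3 (0.98 log units; beyond the scatter), a fall that the single earlier step could only suggest. For compound 3 the value < 3 mL.min-1.g-1 is a limit of the assay and not a number. A group larger than hydrogen at this place, between two ring nitrogen atoms, therefore need not bring a high number: among the three compounds shown, only the methylsulfanyl of compound 2 goes with one.

From the compounds shown here alone, the step from hydrogen to methyl cannot be read, and whether methyl differs at all from hydrogen here stays unknown, because both compounds rest on the same limit: the limit of < 3 mL.min-1.g-1 in this assay, at which 2 of the 3 values shown sit. Going by these compounds, it also remains open whether methoxy, ethyl or an amine at this carbon would stay low like methyl or rise like methylsulfanyl.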